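Methoxy on the anilino ring of a thiazole amide series

The source may hold more compounds than are shown below. What is called first, only, known or untested is meant among the compounds shown, and "the series" means these compounds.

Measured so far:
compound 1 `Cc1nc(SCC(=O)Nc2nc(-c3ccc(Cl)cc3)cs2)n(Nc2ccccc2)c1C` — 41400 nM
compound 2 `Cc1ccc(Nn2c(SCC(=O)Nc3nc(-c4ccccc4)cs3)nc(C)c2C)cc1` — > 100000 nM

In a functional assay on KM12 cells (Homo sapiens) for antiproliferative activity, read by sulforhodamine B assay, with a stated time of 48 h (a higher number here means that more compound is tolerated, a lower number that less compound is tolerated), compound 1 gives 41400 nM. For the measured compounds named here, compound 1 holds the only number among the two values; the other value shown is a limit. In this assay compound 2 reaches only the limit > 100000 nM, which is a limit of the assay and not a number (the limit of > 100000 nM in this assay, at which 1 of the 2 values shown sits). Going by the values given here, no pair of measured compounds differs in one place, so no measured step exists here, and compound 2 differs from compound 1 in more than one place.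

Compound 3 `COc1ccc(Nn2c(SCC(=O)Nc3nc(-c4ccc(Cl)cc4)cs3)nc(C)c2C)cc1` is not yet measured. It differs from compound 1 by methoxy in place of hydrogen on an aromatic carbon, on the six-membered ring para to a large group. Among the compounds with values here, with no measured step to lean on, the expectation for compound 3 is a step from compound 1 of a 1.4-fold higher number from compound 1 to compound 3 (0.16 log units; within the scatter), which is not beyond the scatter, with a clear chance that only a limit is reported. The estimate for compound 3 is 60000 nM, with a range from 25000 nM to 150000 nM.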

Compound 3, concentration lethal to 50% of the cells: > 100000 nM
Compound 3 ended at the assay's limit (the forecaster's own chance of this, stated with the estimate: 35%); middle value at least 1.6-fold (0.22 log units) away from the limit.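

In this assay, for the compounds shown here, methoxy in place of hydrogen on an aromatic carbon, para to a large group, gives an at least 2.4-fold higher number from compound 1 to compound 3 (0.38 log units; beyond the scatter), the only measured step so far and one beyond the scatter. This shows that the position is not neutral to the change: with hydrogen there, compound 1 keeps a measurable number, whereas methoxy moves the read-out out of the measurable range. Compound 3 reaches only a limit of the assay and not a number, so the step gives a minimum and its full size stays unknown: the limit of > 100000 nM in this assay, at which 2 of the 3 values shown sit.

Open, as far as these compounds go, is whether fluorine, a hydroxyl or an amine in the same place would keep a measurable number. Also open, from the compounds shown here alone, is whether a longer chain such as ethoxy would behave as methoxy does here.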